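Aryl amide exchange at the weak end of the series

A few compounds are considered here, and "the series" means these few. Any claim that something is new, unique, unknown or untested is made for them only; others in the source may bear on it.

Compound 2 `O=C(COc1ccc(/C=C2\SC(=O)NC2=O)cc1)Nc1cccc([N+](=O)[O-])c1` in a functional assay on KB cells (Homo sapiens) for inhibition (a lower number here means a stronger inhibitor of growth, a higher number a weaker inhibitor of growth), gives only a limit, > 100000 nM. This limit is the limit of > 100000 nM in this assay, at which 1 of the 2 values shown sits. Compound 1 `Cc1cccc(NC(=O)COc2ccc(/C=C3\SC(=O)NC3=O)cc2)n1` in this assay gives 75000 nM. Among the measured compounds shown here, the step of an at least 1.3-fold higher number from compound 1 to compound 2 (0.12 log units; that floor lies within the scatter) is the only measured change at the amide-type nitrogen and sits at the floor of the scatter. Compound 3 `O=C(COc1ccc(/C=C2\SC(=O)NC2=O)cc1)Nc1ccc(F)cc1` differs from compound 2 by 4-fluorophenyl in place of 3-nitrophenyl on an amide-type nitrogen. Given the small size of the step from compound 1 to compound 2, no change beyond the scatter is expected. The step expected from compound 2 to compound 3 is a number no higher from compound 2 to compound 3 (the limit leaves the size open). Compound 3 is expected in this assay at 100000 nM, within 40000 nM to 250000 nM.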

Compound 3, concentration for 50% growth inhibition: > 100000 nM
Compound 3: no number, only a limit; the forecaster's own chance of this, stated with the estimate: 55%; the middle value lies on the limit itself.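

Compound 3 also gives only a limit: the limit of > 100000 nM in this assay, at which 2 of the 3 values shown sit. Thus 4-fluorophenyl on the amide-type nitrogen, like 3-nitrophenyl, gives no measurable number in this assay, and the change from 6-methylpyridin-2-yl reads only as an at least 1.3-fold higher number from compound 1 to compound 3 (0.12 log units; that floor lies within the scatter). The step between the two limit compounds cannot be read, so these two aryl groups cannot be ordered.

Going by these compounds, whether any group at this position gives growth inhibition clearly stronger than in compound 1 stays open. A 4-aminophenyl or 4-carboxyphenyl group on this nitrogen would be one such case.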